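Moving a Side Chain Between Two Cores: Growth Inhibition Compared

The source may hold more compounds than are shown below. What is called first, only, known or untested is meant among the compounds shown, and "the series" means these compounds.

Measured compounds:
compound 1, `O=C(COc1ccc2oc(-c3ccccc3)cc(=O)c2c1)Nc1ccc(F)cc1`, in a functional assay on NPC-TW01 cells (Homo sapiens) for antiproliferative activity, read by MTT assay, with a stated time of 72 h; on this read-out lower numbers stand for stronger inhibition of growth and higher numbers for weaker inhibition of growth: 740 nM
compound 2, `COc1ccc(NC(=O)COc2ccc3oc(-c4ccccc4)cc(=O)c3c2)cc1`: 710 nM
compound 3, `O=C(COc1ccc2c(=O)cc(-c3ccccc3)oc2c1)Nc1ccc(F)cc1`: > 10000 nM

Compound 1 and compound 2 share one core and differ only at the aryl amide end, (methoxy in place of fluoro on an aromatic carbon). The step of a 1.0-fold lower number from compound 1 to compound 2 (0.02 log units; within the scatter) shows that this exchange left the growth inhibition essentially where it was. Compound 3 carries the same side chain as compound 1 on a core built from the same atoms joined differently; the difference between the two cores is not broken down here. For compound 3 the assay gives only a limit, (the limit of > 10000 nM in this assay, at which 1 of the 3 values shown sits), and not a number.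

Compound 4, `COc1ccc(NC(=O)COc2ccc3c(=O)cc(-c4ccccc4)oc3c2)cc1`, has not yet been measured. It stands to compound 3 exactly as compound 2 stands to compound 1: the same change, (methoxy in place of fluoro on an aromatic carbon), at the same place. Since that change made no difference on the first core, as a 1.0-fold lower number from compound 1 to compound 2 (0.02 log units; within the scatter) shows, compound 4 is expected to follow compound 3 and to remain at or beyond the limit of this assay, so that the step that the limit leaves unreadable from compound 3 to compound 4 is expected to be small. The estimate for compound 4 is 15000 nM, within a range from 7000 nM to 40000 nM, with a high chance that only a limit is reported.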

Compound 4, concentration for 50% growth inhibition: 5970 nM
The estimate for compound 4 lay 2.5-fold (0.40 log units) above the measured number; measured number below the stated range.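

In this assay, methoxy in place of fluoro on the second core gives an at least 1.6-fold lower number from compound 3 to compound 4 (0.22 log units; that floor lies within the scatter). Set beside the same change on the first core, the two steps read as follows: the same change on two cores in this assay, a 1.0-fold lower number (0.02 log units; within the scatter) from compound 1 to compound 2 and an at least 1.6-fold lower number (0.22 log units; that floor lies within the scatter) from compound 3 to compound 4; the limit leaves it open whether they differ. Going by these compounds, compound 3 gives only a limit of the assay, > 10000 nM, so the true size of the step on the second core stays unknown: it may match the step on the first core or be much larger, and the pairs neither show that the change carries over unaltered from one core to the other nor show that it does not.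

The compounds shown leave open how either core would respond to other groups in the place of the fluoro and methoxy on the aromatic ring of the amide end, such as chloro, trifluoromethyl, an amine or a carboxylic acid. They also leave open whether a longer chain in the side chain, or a different group in place of the unsubstituted phenyl on the core, would alter the growth inhibition seen on either core.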